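Methoxy in Place of Hydrogen at the Solubility Ceiling

The compounds below may be only part of what the source reports. "The series", "measured", "known", "first", "only" and "open" are said of these compounds alone.

Compound 1 `CC(C)Nc1nc(NCc2ccco2)c2ccccc2n1` was run in a physicochemical assay for solubility, at pH 2; on this read-out lower numbers stand for lower solubility and higher numbers for higher solubility. In this assay compound 1 gives >= 30000 nM, which is a limit of the assay and not a number. Compound 2 `COc1ccc2c(NCc3ccco3)nc(NC(C)C)nc2c1` gives >= 30000 nM, again a limit. The step that the two limits leave unreadable from compound 1 to compound 2 cannot be read because of the limit of >= 30000 nM in this assay, at which 2 of the 2 values shown sit. Compound 3 `COc1cccc2nc(NC(C)C)nc(NCc3ccco3)c12` carries methoxy in place of hydrogen on an aromatic carbon. Among the measured compounds shown here, no measured step supplies a readable size for such a change, so no direction beyond the scatter can be drawn from it. Compound 3 is therefore expected near 30000 nM, between 10000 nM and 100000 nM, most probably reported again as a limit. The step of a number no higher from compound 1 to compound 3 (the limit leaves the size open) is estimated to stay within the usual scatter.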

Compound 3, solubility: >= 30000 nM
Compound 3 ended at the assay's limit; the forecaster's own chance of this, stated with the estimate: 80%; the middle value lies on the limit itself.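

No size can be read for the step from compound 1 to compound 3, as both stand at a limit: the limit of >= 30000 nM in this assay, at which 3 of the 3 values shown sit.

The compounds shown leave open where each truly lies in this assay, and whether methoxy in place of hydrogen on an aromatic carbon changes that read-out at all.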